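The source may hold more compounds than are shown below. What is called first, only, known or untested is meant among the compounds shown, and "the series" means these compounds.

The study compares four compounds in a physicochemical assay for lipophilicity, using the shake flask method, in phosphate buffer, measured as octanol-water partition, with a stated time of 24 h, at pH 7.4, tested at 100 uM; on this read-out lower numbers stand for lower lipophilicity and higher numbers for higher lipophilicity. Compound 1, with the structure `Cc1cc(OCc2cccc(-c3c(C)cc(OCCCS(C)(=O)=O)cc3C)c2)ccc1N(CC(=O)O)C(=O)c1ccccc1`, carries no number in this assay: the entry for compound 1 reads "not determined" (no result reported). Compound 2, with the structure `CC(=O)N(CC(=O)O)c1ccc(OCc2cccc(-c3c(C)cc(OCCCS(C)(=O)=O)cc3C)c2)cc1C`, likewise carries no number: the entry for compound 2 reads "not determined" (no result reported). Going by the values given here, compound 3, with the structure `Cc1cc(O)cc(C)c1-c1cccc(COc2ccc(OCC(=O)O)c(F)c2)c1`, is the one compound with a number: in this assay compound 3 gives 2.37. Among the compounds with values here, since compound 1 and compound 2 offer no figure, compound 3 stands alone, and no step between two measured compounds can be read from the set.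

Compound 4, with the structure `COc1cc(C)c(-c2cccc(COc3ccc(OCC(=O)O)c(F)c3)c2)c(C)c1`, has not yet been measured in this assay. It differs from compound 3 in one place: methyl in place of hydrogen on an oxygen on an aromatic ring. Put the other way, the hydroxy of compound 3 becomes the methoxy of compound 4, so that 4-hydroxy-2,6-dimethylphenyl turns into 4-methoxy-2,6-dimethylphenyl.

Within the data shown here, with no measured step in the set to lean on, the expectation for compound 4 rests on the single value of compound 3 and on the change itself. For the step from compound 3 to compound 4 an increase of a number 0.48 log units higher from compound 3 to compound 4 (beyond the scatter) is expected, a rise that should stand somewhat beyond the scatter of the method. Compound 4 is therefore estimated at 2.85 in this assay, with the range running from 2.45 to 3.3.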

Compound 4, distribution coefficient: 3.2
For compound 4 the middle estimate is 0.35 log units below the measured one, within the range that was stated.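

Until now the set held a single number, so nothing could be said about how this position responds to change. In this assay, methyl in place of hydrogen on the oxygen on the aromatic ring gives a number 0.83 log units higher from compound 3 to compound 4 (beyond the scatter), and this one change, from 4-hydroxy-2,6-dimethylphenyl to 4-methoxy-2,6-dimethylphenyl, is enough to move the read-out by more than the usual scatter while the rest of the structure stays the same. Nothing at hand accounts for the size of this rise, so the step stands as an observation about this pair alone.

What the compounds shown leave open is how the read-out would respond to other groups on this oxygen or in its place, such as ethyl, a longer chain ending in an amine, or a carboxylic acid directly on the ring. They also leave open whether the same exchange of hydroxy for methoxy would give a step of similar size on another core, since this pair is the only one that can be read and steps involving compound 1 or compound 2 cannot be read.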